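Replacing the Cyclopropyl Pyrazole Group of Compound 3

A few compounds are considered here, and "the series" means these few. Any claim that something is new, unique, unknown or untested is made for them only; others in the source may bear on it.

Values measured so far in a physicochemical assay for lipophilicity, at pH 7.4; on this read-out higher numbers stand for higher lipophilicity and lower numbers for lower lipophilicity
compound 1 `CN(C)C(=O)C1CCN(c2cnccc2-c2ccccn2)CC1` gives 1.2
compound 2 `Cc1ccn(-c2ccncc2N2CCC(C(=O)N(C)C)CC2)n1` gives 1.5
compound 3 `CN(C)C(=O)C1CCN(c2cnccc2-n2cc(C3CC3)cn2)CC1` gives 2.1

Compound 3 stands highest of the three. Compound 4 `Cc1cnc(-c2ccncc2N2CCC(C(=O)N(C)C)CC2)s1`, not yet measured, carries 5-methyl-1,3-thiazol-2-yl in place of 4-cyclopropyl-1H-pyrazol-1-yl on an aromatic carbon, opposite the ring nitrogen (5-methyl-1,3-thiazol-2-yl in place of 4-cyclopropyl-1H-pyrazol-1-yl on an aromatic carbon). Going by the values given here, no measured step makes this exact swap, but three steps changed the group at this same place: a number 0.60 log units higher from compound 2 to compound 3 (beyond the scatter), a number 0.90 log units higher from compound 1 to compound 3 (beyond the scatter), and a number 0.30 log units higher from compound 1 to compound 2 (within the scatter). Both other groups gave lower numbers than 4-cyclopropyl-1H-pyrazol-1-yl, so a modest drop in this assay is expected, estimated as a number 0.40 log units lower from compound 3 to compound 4 (beyond the scatter). For compound 4 the estimated value is 1.7, with an expected range from 1.3 to 2.1.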

Compound 4, distribution coefficient: 2
Compound 4: middle estimate off by 0.30 log units, on the low side, within the range that was stated.
By their numbers in this assay, from the lowest: compounds 1 and 2 (each within the scatter of the next); then compounds 4 and 3 (each within the scatter of the next).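

In this assay, 5-methyl-1,3-thiazol-2-yl matches 4-cyclopropyl-1H-pyrazol-1-yl at this place (a number 0.10 log units lower from compound 3 to compound 4 (within the scatter)), although it brings fewer heavy atoms and no three-membered ring. It also stands clear of the two other groups tried here (a number 0.50 log units higher from compound 2 to compound 4 (beyond the scatter); a number 0.80 log units higher from compound 1 to compound 4 (beyond the scatter)), so a large group with a cyclopropyl ring is not needed for a number at this level. No measurement at hand bears on why these steps have this size.

Still open, going by these compounds, is whether the sulfur or the methyl of the new ring counts for more, since the two enter together. Also open, on these data alone, is how this assay would respond to an amine or a carboxylic acid at this place.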